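Carbamoyl for sulfonamide on the core aryl group

The source may hold more compounds than are shown below. What is called first, only, known or untested is meant among the compounds shown, and "the series" means these compounds.

For the measured compounds named here, compound 1 `Cn1nc2c(=O)n(CC3(O)CCN(Cc4ccc(-c5ccco5)cc4Cl)CC3)cnc2c1-c1ccc(CNS(C)(=O)=O)cc1` gives 65.3 nM in an assay on isolated protein for inhibition of ubiquitin carboxyl-terminal hydrolase 7 (Homo sapiens), with stated times of 30 min and 2 h (on this read-out lower numbers stand for stronger inhibition and higher numbers for weaker inhibition), the lowest of the three numbers measured so far. Compound 3 `Cc1ccc(-c2ccc(CN3CCC(O)(Cn4cnc5c(-c6ccc(CN)cc6)n(C)nc5c4=O)CC3)c(Cl)c2)s1` gives 101 nM, and the two values lie within the scatter of each other. Compound 2 `Cn1nc2c(=O)n(CC3(O)CCN(Cc4ccc(-c5n[nH]c(=O)o5)cc4Cl)CC3)cnc2c1-c1ccc(CN)cc1` gives 171 nM, beyond the scatter from compound 1. Going by the values given here, the only single-change step measured, a 1.7-fold lower number from compound 2 to compound 3 (0.23 log units; within the scatter), concerns the aromatic ring on the benzyl side and says nothing about the group on the aryl attached to the core.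

Compound 4 `Cn1nc2c(=O)n(CC3(O)CCN(Cc4ccc(-c5ccco5)cc4Cl)CC3)cnc2c1-c1ccc(C(N)=O)cc1` carries carbamoyl in place of (methanesulfonamido)methyl on an aromatic carbon, at the position para to a large group. Among the compounds with values here, no measured step bears on this change: compounds 2 and 3 carry an aminomethyl group there, but they differ from compound 1 at the benzyl side as well, so their values give no clean comparison. Both the leaving and the entering group keep one hydrogen-bond donor. In this assay compound 4 is therefore expected near compound 1, with a step of a 1.4-fold higher number from compound 1 to compound 4 (0.14 log units; within the scatter) expected, and an estimate of 90 nM with a range from 30 nM to 300 nM.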

Compound 4, half-maximal inhibitory concentration: 80.8 nM
Estimate against measurement, compound 4: 1.1-fold (0.05 log units) above; the measured number falls inside the stated range.
By their numbers in this assay, from the lowest: compounds 1, 4, 3 and 2 (each within the scatter of the next, the first and the last beyond it).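

On the aryl group attached to the shared core, carbamoyl in place of (methanesulfonamido)methyl gives a 1.2-fold higher number from compound 1 to compound 4 (0.09 log units; within the scatter) in this assay. For the compounds shown here, this is the first single-change reading at this place, and it shows that carbamoyl and (methanesulfonamido)methyl cannot be told apart on this read-out. No measurement on hand gives a reason for this result.

The aminomethyl group of compounds 2 and 3 still has no clean comparison with either group, as those compounds also differ on the benzyl side. As far as these compounds go, whether a carboxylic acid, a longer chain such as 2-aminoethyl, or a bare hydrogen at this place would read the same remains open.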